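Swapping the Halogenated Acyl Group on a Shared Core

A few compounds are considered here, and "the series" means these few. Any claim that something is new, unique, unknown or untested is made for them only; others in the source may bear on it.

Compound 1 `COc1ccc(CN(C(=O)C(C)Br)c2cc(OC)c(OC)c(OC)c2)cc1O` — 160 nM
Compound 2 `C/C=C/C(=O)N(Cc1ccc(OC)c(OC)c1)c1cc(OC)c(OC)c(OC)c1` — 39100 nM

In a functional assay on KYSE-450 cells (Homo sapiens) for inhibition, read by MTT assay, with a stated time of 48 h (on this read-out higher numbers stand for weaker inhibition and lower numbers for stronger inhibition), compound 1 gives 160 nM, the lowest of the two numbers shown; compound 2 gives 39100 nM, a gap well beyond the usual scatter. Compound 3 `COc1ccc(CN(C(=O)CCl)c2cc(OC)c(OC)c(OC)c2)cc1O` has not yet been measured. It differs from compound 1 in one place: chloromethyl in place of 1-bromoethyl on a carbonyl carbon. Among the measured compounds shown here, no step between measured compounds covers such a change, so the expectation rests on compound 1 alone. A small step toward a higher number is expected, a 2.2-fold higher number from compound 1 to compound 3 (0.34 log units; beyond the scatter), within or near the scatter. Compound 3 is estimated at 350 nM, with a range from 70 nM to 2500 nM.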

Compound 3, half-maximal inhibitory concentration: 210 nM
For compound 3 the middle estimate is 1.7-fold (0.22 log units) above the measured one; the measured number falls inside the stated range.
By their numbers in this assay, from the lowest: compounds 1 and 3 (each within the scatter of the next); then compound 2.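

The swap in this assay reads as a 1.3-fold higher number from compound 1 to compound 3 (0.12 log units; within the scatter) and so leaves compound 1 and compound 3 indistinguishable. At this place on the carbonyl carbon, then, chloromethyl can stand in for 1-bromoethyl, even though the halogen and the carbon count both differ. Nothing measured here explains this match.

Because both groups carry a halogen, the compounds shown leave open whether any halogen is needed at all. Plain ethyl or aminomethyl on that carbonyl carbon would address this, while bromomethyl would separate the halogen from the chain.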